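The source may report more compounds than this note shows. Statements on the series, on what has been measured and on what is new or still open speak of the compounds shown alone.

Three compounds share one core and differ only in the group on a saturated chain carbon bound to an aromatic carbon and a double-bonded chain carbon. Compound 1 `O=C1NC(=O)/C(=C/C(c2ccc(-c3ccc4cccc(F)c4c3)[nH]c2=O)C2CC2)O1` carries a cyclopropyl there; in a functional assay on CHO cells for antagonist activity at prostaglandin E2 receptor EP3 subtype (Homo sapiens), read by cAMP accumulation, with a stated time of 30 min (a lower number here means a stronger inhibitor, a higher number a weaker inhibitor), compound 1 gives 33 nM. Compound 2 `O=C1NC(=O)/C(=C/C(c2ccc(-c3ccc4cccc(F)c4c3)[nH]c2=O)C2CCCC2)O1` carries a cyclopentyl and gives 7 nM, which is a 4.7-fold lower number from compound 1 to compound 2 (0.67 log units; beyond the scatter). Compound 3 `O=C1NC(=O)/C(=C/C(c2ccccc2)c2ccc(-c3ccc4cccc(F)c4c3)[nH]c2=O)O1` carries a phenyl and gives 190 nM; this is the highest of the three numbers, with a 5.8-fold higher number from compound 1 to compound 3 (0.76 log units; beyond the scatter) and a 27-fold higher number from compound 2 to compound 3 (1.43 log units; beyond the scatter). Compound 4 `O=C1NC(=O)/C(=C/C(Cc2ccccc2)c2ccc(-c3ccc4cccc(F)c4c3)[nH]c2=O)O1` differs from compound 3 by benzyl in place of phenyl on a saturated chain carbon bound to an aromatic carbon and a double-bonded chain carbon. Among the compounds with values here, no measured step shows this exact change, but the three steps show that this position moves the number by a modest to large amount, and that the saturated groups sit lower than the phenyl. A benzyl again attaches through a saturated carbon, so compound 4 is expected to move a 3.2-fold lower number from compound 3 to compound 4 (0.50 log units; beyond the scatter), toward the numbers of compounds 1 and 2. The estimate for compound 4 in this assay is 60 nM, with a range from 15 nM to 250 nM.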

Compound 4, half-maximal inhibitory concentration in the prostaglandin E2 receptor EP3 subtype assay: 200 nM
The estimate for compound 4 lay 3.3-fold (0.52 log units) below the measured number; the range from low to high includes it.
By their numbers in the prostaglandin E2 receptor EP3 subtype assay, from the lowest: compound 2; then compound 1; then compounds 3 and 4 (each within the scatter of the next).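

In the prostaglandin E2 receptor EP3 subtype assay, benzyl and phenyl cannot be told apart, with a 1.1-fold higher number from compound 3 to compound 4 (0.02 log units; within the scatter), so attachment through a saturated carbon does not by itself bring the number toward those of the cyclopropyl and cyclopentyl compounds. Benzyl stays well apart from both of those rings, with a 6.1-fold higher number from compound 1 to compound 4 (0.78 log units; beyond the scatter) and a 29-fold higher number from compound 2 to compound 4 (1.46 log units; beyond the scatter), and among these four compounds the lower numbers belong only to the two saturated rings. The same change that leaves this number in place has a large effect in a physicochemical assay for solubility, measured as kinetic solubility, at pH 2; a lower number here means a less soluble compound, a higher number a more soluble compound: the measured solubility of compound 3, 15400 nM, and of compound 4, 900 nM, a 17-fold lower number (1.23 log units; beyond the scatter). In the physicochemical assay compound 3 gives 15400 nM and compound 4 gives 900 nM.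

On these data alone, it stays open whether the lower numbers extend to saturated groups in general, which a cyclohexyl or an isobutyl chain on this carbon would test. An amine or a carboxylic acid here would show how a group unlike any of these four behaves.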